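The source may hold more compounds than are shown below. What is called first, only, known or untested is meant among the compounds shown, and "the series" means these compounds.

Of the compounds shown here, three built on one shared core have been measured in a functional assay on the whole organism with Mus musculus as the target, with a stated time of 90 min, at a dose of 25 umol/kg by the oral route; a higher number here means a stronger effect of the compound at the dose given, a lower number a weaker effect. Compound 1 `N=C(N)NCCC[C@H](NC(=O)CN(c1nc(Cl)nc2c1ncn2C1CCCCO1)C1CC1)C(=O)OCc1ccccc1` gives 61.6% in this assay. Compound 2 `O=C(CN(c1nc(Cl)nc2c1ncn2C1CCCCO1)C1CC1)N[C@@H](CC(=O)OCc1ccccc1)C(=O)OCc1ccccc1` gives 25.1%, and compound 3 `O=C(CN(c1nc(Cl)nc2c1ncn2C1CCCCO1)C1CC1)N[C@@H](CCC(=O)OCc1ccccc1)C(=O)OCc1ccccc1` gives 25.2%. Compound 3 thus stands second highest of the three: compound 2 lies within the scatter of it, and compound 1 lies well beyond it, as the step of a number 36.4 percentage points lower from compound 1 to compound 3 (beyond the scatter) shows. The matching step a number 36.5 percentage points lower from compound 1 to compound 2 (beyond the scatter) was of the same size, whereas the step of a number 0.1 percentage points higher from compound 2 to compound 3 (within the scatter) stayed within the scatter.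

Compound 4 `CC(C)C[C@H](NC(=O)CN(c1nc(Cl)nc2c1ncn2C1CCCCO1)C1CC1)C(=O)OCc1ccccc1` differs from compound 3 in one place: isopropyl in place of (benzyloxycarbonyl)methyl on a saturated chain carbon, two bonds along the chain from an amide-type nitrogen and a carbonyl carbon. Among the measured compounds shown here, no measured step exchanges the (benzyloxycarbonyl)methyl group for isopropyl, and no step puts a small saturated group of that kind on the chain, so nothing bears on this change directly. What the measured steps do show is that the two large drops, a number 36.5 percentage points lower from compound 1 to compound 2 (beyond the scatter) and a number 36.4 percentage points lower from compound 1 to compound 3 (beyond the scatter), accompanied the loss of the nitrogen-containing groups of compound 1, while lengthening the benzyl-ester chain, a number 0.1 percentage points higher from compound 2 to compound 3 (within the scatter), left the read-out unchanged. Compound 4 carries no nitrogen-containing group at this position. Compound 4 is therefore expected to give about 28% in this assay, somewhere from 8% to 55%. The estimated step of a number 2.8 percentage points higher from compound 3 to compound 4 (within the scatter) is expected to stay within the scatter, with wide uncertainty.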

Compound 4, a percentage reported as activity, at one dose (the size of the read-out at that dose, not a potency): 28.2%
The estimate for compound 4 lay 0.2 percentage points below the measured number, and the stated range covers the measured number.
By their numbers in this assay, from the lowest: compounds 2, 3 and 4 (each within the scatter of the next); then compound 1.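

In this assay, replacing (benzyloxycarbonyl)methyl with isopropyl gives a number 3 percentage points higher from compound 3 to compound 4 (within the scatter) and replacing benzyloxycarbonyl with isopropyl gives a number 3.1 percentage points higher from compound 2 to compound 4 (within the scatter) at this saturated chain carbon. A group of 3 carbon atoms with no ring therefore cannot be told apart from the two larger groups that carry an aromatic ring and two oxygen atoms, so neither that ring nor those oxygens are needed for a read-out at this level. Compound 1 stays apart, with a number 33.4 percentage points lower from compound 1 to compound 4 (beyond the scatter) in going to the small all-carbon chain, which shows that the two benzyl esters were not what set compounds 2 and 3 below compound 1, and among these four compounds only the nitrogen-containing side chain of compound 1 stands out.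

Nothing at hand explains why this side chain stands apart. The compounds shown leave open whether a simple primary amine on a chain of the same length would reach the level of compound 1, and whether a free carboxylic acid in place of a benzyl ester side chain would stay with compounds 2, 3 and 4.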